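Methoxy removal on the pyrazole-side ring: working notes

A few compounds are considered here, and "the series" means these few. Any claim that something is new, unique, unknown or untested is made for them only; others in the source may bear on it.

The series holds compound 1 `COc1ccc(-c2cc(/C=C/C(=O)c3ccc(N)cc3)[nH]n2)cc1`, compound 2 `COc1ccc(-c2cc(/C=C/C(=O)c3ccc(N)cc3)[nH]n2)cc1OC`, compound 3 `COc1cc(C(=O)/C=C/c2cc(-c3cc(OC)c(OC)c(OC)c3)n[nH]2)cc(OC)c1OC` and the unmeasured compound 4 `COc1ccc(-c2cc(/C=C/C(=O)c3cc(OC)c(OC)c(OC)c3)[nH]n2)cc1OC`. In a functional assay on BT-549 cells (Homo sapiens) for cytotoxicity, read by sulforhodamine B assay, with a stated time of 48 h, tested at 1 uM (on this read-out lower numbers stand for a stronger effect and higher numbers for a weaker effect at the one concentration tested), compound 1 gives 77%, compound 2 gives 80% and compound 3 gives 85%; the three lie within the scatter of one another. Compound 1 differs from compound 2 by hydrogen in place of methoxy on an aromatic carbon, and in this assay this made a number 3 percentage points lower from compound 2 to compound 1 (within the scatter). The difference between the cores of compound 2 and compound 3 is not broken down here. Compound 4 arises from compound 3 by hydrogen in place of methoxy on an aromatic carbon; the place differs in being also meta to a methoxy group, so this is the same kind of change, not the same. Because the earlier step was a number 3 percentage points lower from compound 2 to compound 1 (within the scatter), the step from compound 3 to compound 4 is expected to be a number 2 percentage points lower from compound 3 to compound 4 (within the scatter) in this assay. Compound 4 is accordingly estimated at 83% in this assay, between 70% and 96%.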

Compound 4, a percentage reported as activity, at one concentration (the size of the read-out at that concentration, not a potency): 70%
Compound 4: the middle estimate sits 13 percentage points above what was measured; the measured number falls inside the stated range.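

In this assay, hydrogen in place of methoxy on an aromatic carbon gives a number 15 percentage points lower from compound 3 to compound 4 (beyond the scatter). Set beside the earlier step on the other core, the new step does not separate from it, so these two cases give no sign that the change behaves differently from one core to the other: the same change on two cores in this assay, a number 3 percentage points lower (within the scatter) from compound 2 to compound 1 and a number 15 percentage points lower (beyond the scatter) from compound 3 to compound 4, 12 percentage points apart, within the scatter of two such steps This does not show that the change carries over with the same size, as each core contributes a single step, only the new step lies beyond the scatter, and the place of the change is not identical on the two cores.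

The compounds shown leave open how this place responds to anything other than methoxy or hydrogen, such as a hydroxyl group, a fluorine atom or a longer chain like ethoxy. They also leave open whether removing any other methoxy group on the core of compound 4 would give a comparable step.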